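Aryl groups at the saturated ring carbon: compounds 3 and 4

This account rests on a few compounds, and the source may have more. Where it says the series, first, only, none or still open, it means among the compounds named here.

Measured compounds in an assay on Sf9 cells for inhibition of serine/threonine-protein kinase 4 (Homo sapiens), read by luminescence and ADP-Glo, with a stated time of 1 h, in the presence of a further agent that is not named here; on this read-out lower numbers stand for stronger inhibition and higher numbers for weaker inhibition:
Compound 1, `CC1C(=O)N(C)c2cnc(Nc3ccc(S(N)(=O)=O)cc3)nc2N1C`: 313 nM
Compound 2, `CC(C)C1C(=O)N(C)c2cnc(Nc3ccc(S(N)(=O)=O)cc3)nc2N1C`: 254 nM
Compound 3, `CN1C(=O)C(c2ccc(F)cc2)N(C)c2nc(Nc3ccc(S(N)(=O)=O)cc3)ncc21`: 1770 nM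

Compound 3 carries the highest number of the three in this assay. The two steps that lead to it are a 5.7-fold higher number from compound 1 to compound 3 (0.75 log units; beyond the scatter) and a 7.0-fold higher number from compound 2 to compound 3 (0.84 log units; beyond the scatter), both beyond the scatter, whereas a 1.2-fold lower number from compound 1 to compound 2 (0.09 log units; within the scatter) stays within it. Thus exchanging a small alkyl group for 4-fluorophenyl at this ring carbon costs potency in the shared core, while the alkyl size itself is not resolved.

Compound 4, `COc1ccccc1C1C(=O)N(C)c2cnc(Nc3ccc(S(N)(=O)=O)cc3)nc2N1C`, is unmeasured and differs from compound 3 as follows: 2-methoxyphenyl in place of 4-fluorophenyl on a saturated ring carbon. Among the compounds with values here, no measured step compares one aryl group with another at this carbon, so the measured steps bear on compound 4 only in placing aryl groups at the weaker end of the series. Compound 4 is therefore expected to remain near compound 3, with the step of a 1.2-fold lower number from compound 3 to compound 4 (0.07 log units; within the scatter) estimated to stay within the scatter. The estimate for compound 4 in this assay is 1500 nM, with a range from 500 nM to 4500 nM.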

Compound 4, half-maximal inhibitory concentration: 251 nM
Compound 4: the middle estimate sits 6.0-fold (0.78 log units) above what was measured, outside the stated range (below it).
By their numbers in this assay, from the lowest: compounds 4, 2 and 1 (each within the scatter of the next); then compound 3.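

In this assay, an aryl group at this saturated ring carbon does not by itself cost potency: 2-methoxyphenyl in place of 4-fluorophenyl gives a 7.1-fold lower number from compound 3 to compound 4 (0.85 log units; beyond the scatter), a step beyond the scatter between two aryl groups. Against the alkyl groups, the same aryl group gives a 1.0-fold lower number from compound 2 to compound 4 (0.01 log units; within the scatter) and a 1.2-fold lower number from compound 1 to compound 4 (0.10 log units; within the scatter), both within the scatter, so the weak number of compound 3 belongs to 4-fluorophenyl and not to aryl groups in general. Nothing available explains the gap between the two aryl groups.

The step from compound 3 to compound 4 changes both the substituent and its place on the phenyl ring, and these two changes remain unseparated. Going by these compounds, how unsubstituted phenyl, or a chain ending in an amine or a carboxylic acid, would read at this carbon remains open.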